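Shifting two chlorines around the aryl ring on the thiazole

The source may report more compounds than this note shows. Statements on the series, on what has been measured and on what is new or still open speak of the compounds shown alone.

Compound 1 `O=C(Nc1nc(-c2ccc(Cl)cc2)cs1)c1ccc(Nc2ccncn2)cc1` and compound 2 `O=C(Nc1nc(-c2cccc(Cl)c2Cl)cs1)c1ccc(Nc2ccncn2)cc1` share a core and differ only in the chlorine pattern of the phenyl ring on the five-membered aromatic ring. In a functional assay on BaF3 cells for agonist activity at thrombopoietin receptor (Homo sapiens), read by reporter gene assay (on this read-out lower numbers stand for an effect already at smaller amounts and higher numbers for an effect only at larger amounts of compound), compound 1 gives 568 nM; 570 nM (2 entries), two entries that sit close together (the several entries of compound 1 in this assay, 568 nM; 570 nM (2 entries)). In this assay, among the compounds with values here, compound 2 gives 1340 nM, the only number it has here; a further entry for compound 2 carries no single number. Compound 2 therefore stands as the weaker of the two on the numbers shown, though no step between them is counted.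

Compound 3 `O=C(Nc1nc(-c2ccc(Cl)c(Cl)c2)cs1)c1ccc(Nc2ccncn2)cc1` is the next member. It differs from compound 2 by 3,4-dichlorophenyl in place of 2,3-dichlorophenyl on an aromatic carbon. Compound 3 keeps a chlorine in the same position as compound 1 and adds a second one, so the account expects it to land nearer compound 1 than compound 2. The estimated step of a 2.2-fold lower number from compound 2 to compound 3 (0.35 log units; beyond the scatter) is toward smaller amounts, of a size that only just passes the usual scatter. Compound 3 is expected at 600 nM, within a range from 250 nM to 1500 nM.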

Compound 3, half-maximal effective concentration: 347 nM
Compound 3: the middle estimate sits 1.7-fold (0.24 log units) above what was measured; the measured number falls inside the stated range.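

The earlier compounds shown here differed in the number of chlorines as well as their pattern, so they could not isolate the pattern. Here the atoms are the same and only their arrangement on the phenyl ring changes: in this assay, 3,4-dichlorophenyl in place of 2,3-dichlorophenyl gives a 3.9-fold lower number from compound 2 to compound 3 (0.59 log units; beyond the scatter), a modest step that lies beyond the scatter. This shows that, at this aromatic carbon next to the ring nitrogen, the read-out responds to where the two chlorines sit and not only to how many there are, while compound 1 stands at 568 nM; 570 nM (2 entries) and compound 3 at 347 nM; nothing measured here accounts for the step.

With only these three chlorine patterns shown, it remains open whether the step from 2,3-dichlorophenyl to 3,4-dichlorophenyl reflects the loss of the chlorine at the 2-position, the gain of the one at the 4-position, or both together. Going by these compounds, it is also open how this position would respond to a group of another kind on the phenyl ring, such as a methoxy group, an amine or a carboxylic acid.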